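Notes on an aromatic substituent exchange in a reporter series

A few compounds are considered here, and "the series" means these few. Any claim that something is new, unique, unknown or untested is made for them only; others in the source may bear on it.

compound 1 `CNc1nc(N)nc2ccccc12`: 6.87 uM
compound 2 `CCCCNc1nc(N)nc2cc(CO)ccc12`: 0.1 uM
compound 3 `CCCCNc1nc(N)nc2cccc(C)c12`: 0.3 uM

All three were measured in an ADME assay on HEK293 cells for agonist activity at Toll-like receptor 8 (Homo sapiens), read by a luciferase reporter, with a stated time of 6 h; on this read-out higher numbers stand for an effect only at larger amounts of compound and lower numbers for an effect already at smaller amounts. Among these numbers compound 3 holds the second highest; compound 2 gives a lower number, a gap beyond the scatter, while compound 1 gives a far higher number, also beyond the scatter. Compound 4 `CCCCNc1nc(N)nc2cccc(OCCOC)c12` has not yet been measured. Against compound 3 it carries 2-methoxyethoxy in place of methyl on an aromatic carbon, on an aromatic carbon of a six-membered aromatic ring of carbon only, part of a fused or bridged system of two rings. Within the data shown here, no measured pair shows this exchange, so its direction cannot be read from the series. A step within the scatter or a small loss is expected, a 1.7-fold higher number from compound 3 to compound 4 (0.22 log units; within the scatter). For compound 4 the expected value is 0.5 uM, with a range from 0.1 uM to 2.5 uM.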

Compound 4, minimum effective concentration: 0.2 uM
The estimate for compound 4 lay 2.5-fold (0.40 log units) above the measured number, within the range that was stated.
By their numbers in this assay, from the lowest: compounds 2, 4 and 3 (each within the scatter of the next, the first and the last beyond it); then compound 1.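

In this assay, 2-methoxyethoxy in place of methyl on this aromatic carbon gives a 1.5-fold lower number from compound 3 to compound 4 (0.18 log units; within the scatter). This position therefore accepts the 2-methoxyethoxy chain, with its 2 hydrogen-bond acceptors, in place of a single carbon, and the two numbers remain within the scatter of each other. The data shown give no reason for this tolerance.

As far as these compounds go, whether an amine, a carboxylic acid or a longer ether chain on this carbon would fit equally well remains open. So does how either group here compares with plain hydrogen on the same core.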